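The source may report more compounds than this note shows. Statements on the series, on what has been measured and on what is new or still open speak of the compounds shown alone.

The measured compounds are:

Compound 1, `COc1cc(/C=C/C(=O)C2=C(/C=C/c3ccc(O)c(OC)c3)NC(=O)NC2c2cccc([N+](=O)[O-])c2)ccc1O`, which in a functional assay, with a stated time of 20 min, tested at 50 uM (on this read-out higher numbers stand for a stronger effect at the one concentration tested and lower numbers for a weaker effect), gives 71%.
Compound 2, `COc1cc(/C=C/C(=O)C2=C(/C=C/c3ccc(O)c(OC)c3)NC(=S)NC2c2ccccc2)ccc1O`, which in this assay gives 48%.

Compound 2 holds the lower of the two numbers recorded so far. Going by the values given here, its only neighbour is compound 1, which stands clearly higher, by a gap beyond the usual scatter of this kind of measurement. These two compounds differ in more than one place, so their values say nothing about any single change on its own.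

Compound 3, `COc1cc(/C=C/C(=O)C2=C(/C=C/c3ccc(O)c(OC)c3)NC(=S)NC2c2ccccc2Cl)ccc1O`, differs from compound 2 in one place: chloro in place of hydrogen on an aromatic carbon. The new group is a chloro group placed on an aromatic carbon of a six-membered aromatic ring of carbon only, ortho to a large group, so that the phenyl ring becomes a 2-chlorophenyl ring. Among the compounds with values here, no pair of measured compounds shows a change of this kind, so there is nothing to tell how large its effect should be or in which direction it will run. The expected step is therefore a number 4 percentage points higher from compound 2 to compound 3 (within the scatter), small enough to lie within the usual scatter. Compound 3 is estimated to give 52% in this assay, with a range from 30% to 75%.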

Compound 3, a percentage reported as activity, at one concentration (the size of the read-out at that concentration, not a potency): 60%
Compound 3: middle estimate off by 8 percentage points, on the low side, and the stated range covers the measured number.
By their numbers in this assay, from the lowest: compound 2; then compound 3; then compound 1.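

In this assay, going by these compounds alone, the swap of phenyl to 2-chlorophenyl, with chloro on an aromatic carbon ortho to a large group, gives a number 12 percentage points higher from compound 2 to compound 3 (beyond the scatter) and so is the first change in this set that can be read on its own. It shows that this place on the ring accepts a single chlorine atom with no loss of the read-out, and that this one atom is enough to shift the number by a modest step, though this is the size of the effect at one concentration and not a potency. Nothing measured here bears on what lies behind the step.

A fluoro, methyl or methoxy group on the same carbon, or a chloro group on another carbon of this ring, would tell whether the gain belongs to chlorine itself, to this place, or to any group put there. As far as these compounds go, it also remains open whether the same change would give a similar step on the core of compound 1, which differs from compound 2 in more than one place.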